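Chain length at a carboxylic acid in an inert series

This account rests on a few compounds, and the source may have more. Where it says the series, first, only, none or still open, it means among the compounds named here.

Compound 1 `NC(=O)c1cccc(CN(CCCC(=O)O)C[C@H]2O[C@@H](n3cnc4c(N)ncnc43)[C@H](O)[C@@H]2O)c1` was tested in an assay on cells for inhibition of Nicotinamide N-methyltransferase (Homo sapiens), with stated times of 10 min and 30 min; a lower number here means a stronger inhibitor, a higher number a weaker inhibitor. In this assay compound 1 gives only a limit, > 250000 nM, not a number. Compound 2 `NC(=O)c1cccc(CN(CCCCC(=O)O)C[C@H]2O[C@@H](n3cnc4c(N)ncnc43)[C@H](O)[C@@H]2O)c1` likewise gives only a limit in this assay, > 250000 nM. Compound 3 `Nc1ncnc2c1ncn2[C@@H]1O[C@H](CN(CCCC(=O)O)Cc2cccc(C(=O)O)c2)[C@@H](O)[C@H]1O` also gives only a limit in this assay, > 250000 nM.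

The change from compound 1 to compound 2 is carboxymethyl in place of carboxy on a saturated chain carbon, three bonds along the chain from an amine nitrogen. The step it made is a step that the two limits leave unreadable from compound 1 to compound 2, and it stays unreadable because of the limit of > 250000 nM in this assay, at which 3 of the 3 values shown sit. The two cores differ by hydroxy in place of amino on a carbonyl carbon, and that step is likewise unreadable: a step that the two limits leave unreadable from compound 1 to compound 3.

Compound 4 `Nc1ncnc2c1ncn2[C@@H]1O[C@H](CN(CCCCC(=O)O)Cc2cccc(C(=O)O)c2)[C@@H](O)[C@H]1O` has not yet been measured. For the measured compounds named here, it differs from compound 3 by carboxymethyl in place of carboxy on a saturated chain carbon, three bonds along the chain from an amine nitrogen, which is the same change as the one from compound 1 to compound 2, made at the same place.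

For compound 4 the expected step in this assay is a step that the limit leaves unreadable from compound 3 to compound 4, an expectation resting on compound 1 and compound 2, whose step that the two limits leave unreadable from compound 1 to compound 2 gave no readable shift. Compound 4 is therefore estimated at 300000 nM, within 100000 nM to 1000000 nM, and most likely to be reported as a limit only.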

Compound 4, half-maximal inhibitory concentration: > 250000 nM
Compound 4: a limit, no number (the forecaster's own chance of this, stated with the estimate: 85%); the middle value is on the limit's open side.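

In this assay compound 4 gives only a limit, > 250000 nM. Its steps from compound 3 and from compound 2 cannot be read, because all four compounds sit at the same limit: the limit of > 250000 nM in this assay, at which 4 of the 4 values shown sit.

The compounds shown leave open whether carboxymethyl in place of carboxy, or hydroxy in place of amino, changes inhibition at all.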